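A few compounds are considered here, and "the series" means these few. Any claim that something is new, unique, unknown or untested is made for them only; others in the source may bear on it.

Measured compounds:
Compound 1 `Cc1nc2c3ccccc3ccc2c2nc3c(ccc4ccccc43)c(-c3cccnc3)c12` gives 98.2 ug/mL in a functional assay, read by spectrophotometry, with a stated time of 30 min; on this read-out higher numbers stand for weaker inhibition and lower numbers for stronger inhibition.
Compound 2 `COc1ccc(-c2c3ccc4ccccc4c3nc3c2c(C)nc2c4ccccc4ccc32)cc1` gives 133 ug/mL in this assay.
Compound 3 `Cc1nc2c3ccccc3ccc2c2nc3c(ccc4ccccc43)c(-c3ccccc3N)c12` gives 95.4 ug/mL in this assay.

Compound 3 stands among its two neighbours with no separation that the measurement can resolve: the step of a 1.0-fold lower number from compound 1 to compound 3 (0.01 log units; within the scatter) and the step of a 1.4-fold lower number from compound 2 to compound 3 (0.14 log units; within the scatter) both fall within the usual scatter, as does the step of a 1.4-fold higher number from compound 1 to compound 2 (0.13 log units; within the scatter) between the other two. The three compounds share one core and differ only in the aryl group attached to it, and across the three groups the numbers barely move.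

Compound 4 `Cc1ccc(-c2c3ccc4ccccc4c3nc3c2c(C)nc2c4ccccc4ccc32)cc1` carries the change (4-methylphenyl in place of 2-aminophenyl on an aromatic carbon). The group that enters is a para-substituted phenyl, as is the 4-methoxyphenyl of compound 2, and the group that leaves is the only one among the three that carries a hydrogen-bond donor. The relevant steps, all within the scatter, give no reason to expect movement in either direction in this assay beyond the scatter; the estimated step of a 1.2-fold higher number from compound 3 to compound 4 (0.06 log units; within the scatter) is expected to be small. Compound 4 is therefore expected to give about 110 ug/mL, within a range from 60 ug/mL to 200 ug/mL.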

Compound 4, half-maximal inhibitory concentration: 123 ug/mL
The estimate for compound 4 lay 1.1-fold (0.05 log units) below the measured number; low and high end bracket the measured number.
By their numbers in this assay, from the lowest: compounds 3, 1, 4 and 2 (each within the scatter of the next).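

Exchanging 2-aminophenyl, with 1 hydrogen-bond donor and 1 hydrogen-bond acceptor, for 4-methylphenyl, with 0 of either, gives in this assay the step of a 1.3-fold higher number from compound 3 to compound 4 (0.11 log units; within the scatter), so losing this donor and acceptor from the group at this position produces no resolvable change. Methyl in place of methoxy on the phenyl group gives a 1.1-fold lower number from compound 2 to compound 4 (0.03 log units; within the scatter), and 4-methylphenyl in place of pyridin-3-yl gives a 1.3-fold higher number from compound 1 to compound 4 (0.10 log units; within the scatter), so all four aromatic groups at this position remain unseparated by this measurement. No supporting evidence bears on why these groups stay so close.

All four compounds carry a six-membered aromatic ring at this position, leaving open whether a carboxylic acid, an aliphatic amine or a longer alkyl chain there would move the number beyond the scatter. Also open, going by these compounds, is what the methyl on the shared core contributes, as all four compounds carry it.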